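The compounds below may be only part of what the source reports. "The series", "measured", "known", "first", "only" and "open" are said of these compounds alone.

Measured compounds:
- compound 1 `COc1ccc(F)cc1CNCCCNc1ccnc2cc(CC(C)C)ccc12` gives 2900 nM in an ADME assay on HepG2 cells (Homo sapiens) for cytotoxicity, read by luminescence, CellTiter-Glo and ATP content, with a stated time of 72 h; on this read-out lower numbers stand for an effect already at smaller amounts and higher numbers for an effect only at larger amounts of compound
- compound 2 `COc1ccc(F)cc1CNCCCNc1ccnc2cc(Cc3ccc(F)cc3)ccc12` gives 3530 nM in this assay

The two numbers sit close together: the step of a 1.2-fold higher number from compound 1 to compound 2 (0.09 log units; within the scatter) lies within the scatter, so compound 2 and compound 1 cannot be told apart on this read-out. Going by the values given here, that one step, a 4-fluorophenyl in place of isopropyl on a saturated chain carbon bound to an aromatic carbon, is the only comparison available, and it moved the number hardly at all.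

Compound 3 `COc1ccc(F)cc1CNCCCNc1ccnc2cc(Cc3ccc(F)cc3Cl)ccc12` differs from compound 2 by chloro in place of hydrogen on an aromatic carbon. Among the compounds with values here, no measured step adds a chloro to an aromatic carbon of this kind, so there is nothing that bears directly on it. Given that the one known change left the number essentially unmoved, the step of a 1.0-fold lower number from compound 2 to compound 3 (0.00 log units; within the scatter) is expected to stay within the scatter. Compound 3 is therefore estimated at 3500 nM in this assay, with a range from 1500 nM to 8000 nM.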

Compound 3, half-maximal effective concentration: 2460 nM
Estimate against measurement, compound 3: 1.4-fold (0.15 log units) above; the measured number falls inside the stated range.
By their numbers in this assay, from the lowest: compounds 3, 1 and 2 (each within the scatter of the next).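

In this assay, the position ortho to a large group and meta to a fluoro group accepts chloro in place of hydrogen with a 1.4-fold lower number from compound 2 to compound 3 (0.16 log units; within the scatter), so a change on the aromatic ring itself does not separate the two compounds on this read-out. Replacing isopropyl with the whole 2-chloro-4-fluorophenyl group gives a 1.2-fold lower number from compound 1 to compound 3 (0.07 log units; within the scatter), so this larger exchange cannot be told apart from no change either. No measurement here offers an explanation for these small steps.

From the compounds shown here alone, it remains open whether a carboxylic acid or an amine in place of the chloro would move the number beyond the scatter. Going by these compounds, all three compounds also share the core and the rest of the molecule, so the effect of changes there is unknown.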